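The compounds below may be only part of what the source reports. "The series", "measured", "known", "first", "only" and "open" are said of these compounds alone.

Working notes on a series built on one shared core. Compound 1 `C[C@@H](O)[C@H]1C(=O)N2C(C(=O)OCOC(=O)C(C)(C)C)=C(S[C@@H]3CN[C@H](C(=O)Nc4cccc(C(=O)O)c4)C3)[C@H](C)[C@H]12` is the reference point. In a physicochemical assay for metabolic stability, read by LC-MS, in phosphate buffer, with a stated time of 3 h, at pH 7.4, tested at 50 uM (on this read-out higher numbers stand for a more stable compound and lower numbers for a less stable compound), compound 1 gives > 95%, which is a limit of the assay rather than a number. Compound 2 `C[C@@H](O)[C@H]1C(=O)N2C3=C(S[C@@H]4CN[C@@H](C4)C(=O)Nc4cccc(c4)C(=O)OCOCOC3=O)[C@H](C)[C@H]12` sits at a limit as well: in this assay compound 2 gives > 95%. Compound 3 `CCOC(=O)C1=C(S[C@@H]2CN[C@H](C(=O)Nc3cccc(C(=O)OCC)c3)C2)[C@H](C)[C@@H]2[C@@H]([C@@H](C)OC(C)=O)C(=O)N12` does likewise: in this assay compound 3 gives > 95%, again a limit. Going by the values given here, every value shown so far sits at the limit of > 95% in this assay, at which 3 of the 3 values shown sit, and no step between measured compounds is known. Compound 4 `C[C@@H](O)[C@H]1C(=O)N2C(C(=O)OCOC(=O)OC3CCCCC3)=C(S[C@@H]3CN[C@H](C(=O)Nc4cccc(C(=O)O)c4)C3)[C@H](C)[C@H]12` differs from compound 1 by cyclohexyloxy in place of tert-butyl on a carbonyl carbon. Among the compounds with values here, with no measured step of this kind, no direction beyond the scatter is expected. The expected step is a number no higher from compound 1 to compound 4 (the limit leaves the size open). Compound 4 is therefore expected to give 95%, with a range from 85% to 100%, most likely reported again as a limit.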

Compound 4, percent of the compound remaining: > 95%
Compound 4 gave a limit, no number (the forecaster's own chance of this, stated with the estimate: 70%); the middle value sits exactly at the limit.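

No step can be read from compound 1 to compound 4, as both sit at a limit of the assay: the limit of > 95% in this assay, at which 4 of the 4 values shown sit. The compounds shown leave open whether cyclohexyloxy in place of tert-butyl on a carbonyl carbon changes the read-out at all.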